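Ester at the hydroxymethyl site of the fused core

The source may report more compounds than this note shows. Statements on the series, on what has been measured and on what is new or still open speak of the compounds shown alone.

Going by the values given here, in a functional assay on MCF7 cells (Homo sapiens) for cytotoxicity, read by neutral red uptake, with a stated time of 3 days (on this read-out higher numbers stand for weaker inhibition and lower numbers for stronger inhibition), compound 2 `Nc1ccc(-c2cc(=O)c3c(N)c(F)c(Cl)c(F)c3o2)cc1F` gives 210 nM, the higher of the two numbers measured so far; compound 1 `Nc1ccc(-c2cc(=O)c3c(N)c(F)c(CO)c(F)c3o2)cc1F` gives 62 nM. Among the compounds with values here, the one measured step that bears on the next change is a 3.4-fold higher number from compound 1 to compound 2 (0.53 log units; beyond the scatter). Compound 3 `CCCCCC(=O)OCc1c(F)c(N)c2c(=O)cc(-c3ccc(N)c(F)c3)oc2c1F` differs from compound 2 by ((pentylcarbonyl)oxy)methyl in place of chloro on an aromatic carbon. The entering group carries the same oxygen-bearing methylene as compound 1, so the number is expected to move back toward compound 1, the step from compound 2 to compound 3 being expected as a 1.9-fold lower number from compound 2 to compound 3 (0.28 log units; within the scatter). Compound 3 is therefore expected to give about 110 nM, between 35 nM and 350 nM.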

Compound 3, half-maximal inhibitory concentration: 160 nM
Compound 3: the middle estimate sits 1.5-fold (0.16 log units) below what was measured; the range from low to high includes it.
By their numbers in this assay, from the lowest: compound 1; then compounds 3 and 2 (each within the scatter of the next).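

In this assay, the ester does not hold the number of the free alcohol: a 2.6-fold higher number from compound 1 to compound 3 (0.41 log units; beyond the scatter), so adding pentylcarbonyl to that oxygen counts against this site. Against chloro the picture differs, with a 1.3-fold lower number from compound 2 to compound 3 (0.12 log units; within the scatter), so at this position, ortho to two fluoro groups, a group of 9 heavy atoms cannot be told apart from a single chlorine. No measured evidence bears on the reason for either step.

From the compounds shown here alone, whether an acetyl ester, a longer acyl chain or an aminomethyl group would read like compound 1 or like compound 3 remains open.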